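Tetrazole in place of carboxy on the compound 3 core

This account rests on a few compounds, and the source may have more. Where it says the series, first, only, none or still open, it means among the compounds named here.

Measured compounds in a functional assay on the whole organism (strain Sprague-Dawley) for inhibition, with Rattus norvegicus as the target; on this read-out higher numbers stand for an effect only at larger amounts of compound and lower numbers for an effect already at smaller amounts:
Compound 1 `CCc1ccc2c(=O)c(-c3nn[nH]n3)c[nH]c2c1` gives only a limit, > 10 mg/kg.
Compound 2 `COc1cccc2cc(C(=O)O)cnc12` gives 150 mg/kg.
Compound 3 `O=C(O)c1cnc2cc(C(F)(F)F)ccc2c1` gives only a limit, > 25 mg/kg.

Compound 3 stands at a limit of this assay rather than at a number. Of the three values shown, one sits at the limit of > 25 mg/kg in this assay, at which 1 of the 3 values shown sits, and one sits at the limit of > 10 mg/kg in this assay, at which 1 of the 3 values shown sits, so only compound 2 gives a number at all. Among the compounds with values here, no step between measured compounds differing in one place is available.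

Compound 4 `FC(F)(F)c1ccc2cc(-c3nn[nH]n3)cnc2c1` is compound 3 with 2H-tetrazol-5-yl in place of carboxy on an aromatic carbon. Within the data shown here, compound 1 carries the same 2H-tetrazol-5-yl group on a related core and gives only a limit; compound 2 carries carboxy and gives a number, but these two differ in more than one place and no step between them is computed. The step from compound 3 to compound 4 in this assay is expected to be small, with no clear direction beyond the scatter, a step that the limit leaves unreadable from compound 3 to compound 4. Compound 4 is expected to give about 50 mg/kg, within 15 mg/kg to 200 mg/kg, most likely again reported only as a limit.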

Compound 4, minimum effective dose: 25 mg/kg
Estimate against measurement, compound 4: 2.0-fold (0.30 log units) above; the range from low to high includes it.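

In this assay compound 4 gives a number, 25 mg/kg, the only number shown for a compound carrying 2H-tetrazol-5-yl. Compound 3 gives only a limit, > 25 mg/kg. Placing 2H-tetrazol-5-yl in place of carboxy on this aromatic carbon gives a number no higher from compound 3 to compound 4 (the limit leaves the size open), so this position tolerates the change without loss of a measurable effect in the whole animal, and the size of the step stays open because compound 3 sits at a limit: the limit of > 25 mg/kg in this assay, at which 1 of the 4 values shown sits.

On these data alone, whether 2H-tetrazol-5-yl truly improves on carboxy here remains open until compound 3 has a number rather than a limit. Also open, as far as these compounds go, is how a primary amide or a methylsulfonyl group on this same aromatic carbon would read in this assay.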